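One Methyl Removed from an Aromatic Nitrogen

The source may report more compounds than this note shows. Statements on the series, on what has been measured and on what is new or still open speak of the compounds shown alone.

Of the compounds shown here, three have been measured in a functional assay on A2780 cells (Homo sapiens) for antiproliferative activity, read by MTT assay, with a stated time of 48 h; on this read-out higher numbers stand for weaker inhibition and lower numbers for stronger inhibition. Compound 1 `COc1ccc2c(/C=C/C(=O)c3cc(N)c(OC)c(OC)c3)c[nH]c2c1` gives 204 nM, and compound 2 `COc1ccc2c(/C=C/C(=O)c3cc(N)c(OC)c(OC)c3)cn(C)c2c1` gives 156 nM. Between them lies a single change, (hydrogen in place of methyl on an aromatic nitrogen), and the step was a 1.3-fold higher number from compound 2 to compound 1 (0.12 log units; within the scatter). Compound 3 `COc1ccc2c(/C=C(\C)C(=O)c3cc(OC)c(OC)c([Se]C)c3)cn(C)c2c1` gives 26 nM in this assay, the lowest of the three numbers; the difference between the core of compound 3 and the core of compound 2 is not broken down here.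

Compound 4 `COc1ccc2c(/C=C(\C)C(=O)c3cc(OC)c(OC)c([Se]C)c3)c[nH]c2c1` has not yet been measured in this assay. It differs from compound 3 by hydrogen in place of methyl on an aromatic nitrogen, the same change that separates compound 2 from compound 1, at the same place. Among the compounds shown this change occurs twice, once measured and once not.

Because the measured change gave a 1.3-fold higher number from compound 2 to compound 1 (0.12 log units; within the scatter), a step within the scatter, the corresponding step is expected to be a 1.3-fold higher number from compound 3 to compound 4 (0.12 log units; within the scatter). Nothing else among the three measured compounds bears on this change. In this assay compound 4 is therefore estimated at 34 nM, with a plausible range from 17 nM to 70 nM.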

Compound 4, half-maximal inhibitory concentration: 18 nM
Estimate against measurement, compound 4: 1.9-fold (0.28 log units) above, within the range that was stated.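

In this assay, hydrogen in place of methyl on the aromatic nitrogen gave a 1.4-fold lower number from compound 3 to compound 4 (0.16 log units; within the scatter), so this step, like the earlier one, stays within the scatter. Set side by side, the two steps agree within what repeated measurements allow: the same change on two cores in this assay, a 1.3-fold higher number (0.12 log units; within the scatter) from compound 2 to compound 1 and a 1.4-fold lower number (0.16 log units; within the scatter) from compound 3 to compound 4, 1.9-fold (0.28 log units) apart, within the scatter of two such steps. Among these compounds, on these two cores, then, the change can be carried from one to the other without a step beyond the scatter appearing, and the opposite directions of the two steps carry no weight; this rests on only two pairs, however, and does not show that the same would hold on any other core or in any other assay.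

The compounds shown leave open whether an ethyl group or a longer chain on that nitrogen would behave as methyl and hydrogen do here. The two cores differ in more than one place, and which of those differences accounts for the gap between compound 2 and compound 3 also stays open.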